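Swapping Dimethylamino for Amino Across Two Cores

The source may report more compounds than this note shows. Statements on the series, on what has been measured and on what is new or still open speak of the compounds shown alone.

Compound 2 `COc1ccc(C(=O)c2ccc(OC)c3c2OC(C)(C)C=C3)c(NC(=O)CN(C)C)c1` and compound 1 `COc1ccc(C(=O)c2ccc(OC)c3c2OC(C)(C)C=C3)c(NC(=O)CN)c1` share one core and differ in a single place. In a functional assay on HeLa cells (Homo sapiens) for antiproliferative activity, read by MTT assay, with a stated time of 48 h (a lower number here means a stronger inhibitor, a higher number a weaker inhibitor), compound 2 gives 1050 nM, and compound 1 gives 410 nM; the change amino in place of dimethylamino on a saturated chain carbon bound to a carbonyl carbon made the step of a 2.6-fold lower number from compound 2 to compound 1 (0.41 log units; beyond the scatter). Compound 3 `COc1ccc(C(=O)c2cc(OC)c(OC)c(OC)c2)c(NC(=O)CN(C)C)c1` carries the dimethylamino group on a second core; the difference between the two cores is not broken down here. In this assay compound 3 gives 470 nM. Compound 4 `COc1ccc(C(=O)c2cc(OC)c(OC)c(OC)c2)c(NC(=O)CN)c1` has not yet been measured in this assay; it bears the same change, (amino in place of dimethylamino on a saturated chain carbon bound to a carbonyl carbon), at the same place. The step is expected to read a 2.6-fold lower number from compound 3 to compound 4 (0.42 log units; beyond the scatter), because the same change gave a 2.6-fold lower number from compound 2 to compound 1 (0.41 log units; beyond the scatter) on the other core, a single prior example. Compound 4 is therefore estimated at 180 nM, between 90 nM and 400 nM.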

Compound 4, half-maximal inhibitory concentration: 130 nM
The estimate for compound 4 lay 1.4-fold (0.14 log units) above the measured number, within the range that was stated.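

In this assay, amino in place of dimethylamino gave a 3.6-fold lower number from compound 3 to compound 4 (0.56 log units; beyond the scatter), and the step on the second core matched the one on the first within the scatter: the same change on two cores in this assay, a 2.6-fold lower number (0.41 log units; beyond the scatter) from compound 2 to compound 1 and a 3.6-fold lower number (0.56 log units; beyond the scatter) from compound 3 to compound 4, 1.4-fold (0.15 log units) apart, within the scatter of two such steps. Across these two cores, then, the change carried over, lowering the number on both. Among the compounds shown here, with only two pairs, this does not show that it would hold on any further core, and it does not explain why the number falls.

The compounds shown leave open how a methylamino group, a pyrrolidine ring or a longer chain ending in an amine would read on a saturated chain carbon bound to a carbonyl carbon. From the compounds shown here alone, whether any of these would keep the same step on both cores also remains open.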